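Notes on a three-compound set and a fourth analogue

The compounds below may be only part of what the source reports. "The series", "measured", "known", "first", "only" and "open" are said of these compounds alone.

The series is followed in a functional assay on DU-145 cells (Homo sapiens) for antiproliferative activity, read by MTT assay, with a stated time of 24 h; a lower number here means a stronger inhibitor, a higher number a weaker inhibitor. Compound 1 `COc1ccc(/C=C/C(=O)c2cc(-c3ccc(OC)c(OC)c3)n3nc(-c4ccccc4)cc3n2)cc1` gives 14900 nM. Compound 2 `COc1ccc(-c2cc(C(=O)/C=C/c3ccc(Cl)cc3)nc3cc(-c4ccccc4)nn23)cc1OC` gives 22400 nM; the step of a 1.5-fold higher number from compound 1 to compound 2 (0.18 log units; within the scatter) lies within the scatter. Compound 3 `COc1ccc(-c2cc(/C=C/C(=O)c3ccc(C)c(C)c3)nc3cc(-c4ccccc4)nn23)cc1OC` gives 12100 nM. The steps of a 1.2-fold lower number from compound 1 to compound 3 (0.09 log units; within the scatter) and a 1.9-fold lower number from compound 2 to compound 3 (0.27 log units; within the scatter) are also within the scatter, so the three measured compounds cannot be separated in this assay, and compound 3 sits at one end of the measured numbers only nominally, with compound 1 nearest and compound 2 furthest.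

Compound 4 `COc1ccc(-c2cc(/C=C/C(=O)c3ccccc3)nc3cc(-c4ccccc4)nn23)cc1OC` differs from compound 3 by phenyl in place of 3,4-dimethylphenyl on a carbonyl carbon. The measured steps that bear on the aryl group attached to the carbonyl are those into compound 3, which exchange the aryl ring and the orientation of the chain at once, and neither moved the number beyond the scatter. Removing the two methyl groups from that ring is a smaller change than either of those, so no shift beyond the scatter is expected for compound 4 in this assay: the expected step is a 1.2-fold higher number from compound 3 to compound 4 (0.06 log units; within the scatter). The estimate for compound 4 in this assay is 14000 nM, with a range from 6000 nM to 35000 nM.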

Compound 4, half-maximal inhibitory concentration: 10000 nM
Beside the measured number, compound 4's estimate is 1.4-fold (0.15 log units) above it; measured number inside the range.
By their numbers in this assay, from the lowest: compounds 4, 3, 1 and 2 (each within the scatter of the next, the first and the last beyond it).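

In this assay, within the data shown here, the step of a 1.2-fold lower number from compound 3 to compound 4 (0.08 log units; within the scatter) is the first in this set to change the aryl group on the carbonyl carbon while the chain keeps its orientation, and removing both methyl groups leaves the number within the scatter. Among these compounds, the step of a 2.2-fold lower number from compound 2 to compound 4 (0.35 log units; beyond the scatter) is the first in the set to lie beyond the scatter, if only modestly, but it exchanges the aryl ring and the orientation of the chain at once and cannot be assigned to either change, while the step of a 1.5-fold lower number from compound 1 to compound 4 (0.17 log units; within the scatter) stays within the scatter. No measurement in hand gives a reason for any of these steps.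

Going by these compounds, the effect of reversing the chain on its own remains open, as every step that reverses it also changes the aryl ring. Also open, on these data alone, is whether an amine or a carboxylic acid on the phenyl ring of compound 4, or a longer chain in place of the ethenyl link, would move the number beyond the scatter.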